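A few compounds are considered here, and "the series" means these few. Any claim that something is new, unique, unknown or untested is made for them only; others in the source may bear on it.

Measured compounds in this series:

compound 1 `Cc1ccc2nc(NC(=O)CNC(=O)c3nn(-c4ccccc4)c(=O)c4ccccc34)sc2c1` — 35 nM
compound 2 `COc1ccc(-n2nc(C(=O)NCC(=O)Nc3nc4ccc(C)cc4s3)c3ccccc3c2=O)cc1` — 25 nM
compound 3 `O=C(CNC(=O)c1nn(-c2ccccc2)c(=O)c2ccccc12)Nc1nc2ccc(C(F)(F)F)cc2s1` — 110 nM

Notes. In an assay on L cells for inhibition of Protein-serine O-palmitoleoyltransferase porcupine (Mus musculus), read by reporter gene assay, with a stated time of 24 h (on this read-out lower numbers stand for an effect already at smaller amounts and higher numbers for an effect only at larger amounts of compound), compound 2 gives the lowest of the three numbers. Compound 1 lies within the scatter of it, as a 1.4-fold lower number from compound 1 to compound 2 (0.15 log units; within the scatter) shows, so the two cannot be told apart on these data. Compound 3 stands beyond the scatter, its number well above that of compound 2.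

Compound 4 `COc1ccc(-n2nc(C(=O)NCC(=O)Nc3nc4ccc(Cl)cc4s3)c3ccccc3c2=O)cc1` differs from compound 2 in one place: chloro in place of methyl on an aromatic carbon. Going by the values given here, one measured step bears on this position, a 3.1-fold higher number from compound 1 to compound 3 (0.50 log units; beyond the scatter), where the same methyl gave way to trifluoromethyl and the number rose by a modest amount. The step of a 1.4-fold lower number from compound 1 to compound 2 (0.15 log units; within the scatter) touches the other end of the molecule and does not bear. Among the compounds with values here, no measured pair exchanges methyl for chloro, so the size of that particular step is unknown; only the single exchange at this carbon gives a pointer, and it points upward. Accordingly a small rise in this assay is expected, a 1.6-fold higher number from compound 2 to compound 4 (0.20 log units; within the scatter), possibly within the scatter.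

Compound 4 is estimated at 40 nM, with a range from 14 nM to 110 nM.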

Compound 4, half-maximal effective concentration: 15 nM
The estimate for compound 4 lay 2.7-fold (0.43 log units) above the measured number, and the stated range covers the measured number.
By their numbers in this assay, from the lowest: compounds 4, 2 and 1 (each within the scatter of the next, the first and the last beyond it); then compound 3.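

In this assay, a 1.7-fold lower number from compound 2 to compound 4 (0.22 log units; within the scatter) shows that chloro can take the place of methyl on this aromatic carbon of the six-membered ring with no difference that can be told from the scatter. The earlier exchange at this carbon, trifluoromethyl for methyl in a 3.1-fold higher number from compound 1 to compound 3 (0.50 log units; beyond the scatter), went beyond the scatter, so a higher number is not the outcome of every replacement of this methyl, although that step was read without the methoxy group that compound 2 and compound 4 carry. Nothing measured on these compounds speaks to what lies behind either step.

Open is how far this carbon accepts other groups: the compounds shown say nothing about a bare hydrogen, fluoro, bromo, nitrile, an amine or a carboxylic acid here, so the three substituents present give no trend. Also open is whether chloro behaves the same way without the methoxy group, since the unsubstituted phenyl partner of compound 4 is not among the compounds shown, and the methoxy and chloro exchanges therefore cannot be judged as independent of each other.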